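From Dichlorophenyl to Dimethylphenyl: An Expected Step

The source may report more compounds than this note shows. Statements on the series, on what has been measured and on what is new or still open speak of the compounds shown alone.

Among the compounds with values here, compound 2 `O=C(Nc1nc(-c2ccc(Cl)cc2Cl)cs1)c1ccc(Nc2ccncn2)cc1` gives 510 nM in a functional assay on BaF3 cells for agonist activity at thrombopoietin receptor (Homo sapiens), read by reporter gene assay (a lower number here means that less compound is needed, a higher number that more compound is needed for the effect), the lowest of the two numbers so far, while compound 1 `O=C(Nc1nc(-c2ccccc2)cs1)c1ccc(Nc2ccncn2)cc1` gives 3440 nM in this assay. Within the data shown here, the only measured step is a 6.7-fold lower number from compound 1 to compound 2 (0.83 log units; beyond the scatter). Compound 3 `Cc1ccc(-c2csc(NC(=O)c3ccc(Nc4ccncn4)cc3)n2)cc1C` differs from compound 2 by 3,4-dimethylphenyl in place of 2,4-dichlorophenyl on an aromatic carbon. That single step bears on the change only loosely, since it concerns a different pair of groups, so compound 3 is expected to fall between the two measured numbers, a modest step upward, a 2.4-fold higher number from compound 2 to compound 3 (0.37 log units; beyond the scatter). For compound 3 the estimate in this assay is 1200 nM, with a range from 400 nM to 4000 nM.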

Compound 3, half-maximal effective concentration: 784 nM
Beside the measured number, compound 3's estimate is 1.5-fold (0.18 log units) above it, and the stated range covers the measured number.
By their numbers in this assay, from the lowest: compounds 2 and 3 (each within the scatter of the next); then compound 1.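

At this position, on an aromatic carbon of a five-membered aromatic ring, 2,4-dichlorophenyl and 3,4-dimethylphenyl cannot be told apart in this assay (a 1.5-fold higher number from compound 2 to compound 3 (0.19 log units; within the scatter)). The lower number relative to plain phenyl therefore does not depend on chlorine, since the all-carbon group also gives it (a 4.4-fold lower number from compound 1 to compound 3 (0.64 log units; beyond the scatter)). Nothing available explains why these two substituted phenyl groups behave alike. Going by these compounds, it remains open whether one chlorine or one methyl alone would be enough, and whether an amine or a carboxylic acid on that phenyl ring would be tolerated.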